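Compound 3: (4-bromophenyl)sulfanyl in place of phenylsulfonyl

The source may hold more compounds than are shown below. What is called first, only, known or untested is meant among the compounds shown, and "the series" means these compounds.

Measured so far:
Compound 1 `CC(O)(CS(=O)(=O)c1ccc(F)cc1)c1nc(-c2ccc([N+](=O)[O-])c(C(F)(F)F)c2)no1` gives > 100000 nM in a functional assay on DU-145 cells (Homo sapiens) for cytotoxicity, read by MTT assay (a higher number here means a weaker inhibitor, a lower number a stronger inhibitor), a limit of the assay.
Compound 2 `CC(O)(CS(=O)(=O)c1ccccc1)c1nc(-c2ccc([N+](=O)[O-])c(C(F)(F)F)c2)no1` gives > 100000 nM in this assay, also a limit.

The step that the two limits leave unreadable from compound 1 to compound 2 is unreadable, as the limit of > 100000 nM in this assay, at which 2 of the 2 values shown sit, shows. Compound 2 therefore stands only at a limit in this assay, with no number to build on.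

Compound 3 `CC(O)(CSc1ccc(Br)cc1)c1nc(-c2ccc([N+](=O)[O-])c(C(F)(F)F)c2)no1` differs from compound 2 by (4-bromophenyl)sulfanyl in place of phenylsulfonyl on a saturated chain carbon, two bonds along the chain from an aromatic carbon and an oxygen on a saturated carbon. No measured step bears on this change, since both shown values sit at the limit. For compound 3 the outcome in this assay is expected to remain at or near the limit, estimated at 80000 nM, within 20000 nM to 300000 nM. The step of an at least 1.2-fold lower number from compound 2 to compound 3 (0.09 log units; that floor lies within the scatter) is accordingly expected to be unreadable.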

Compound 3, half-maximal inhibitory concentration: 1600 nM
The estimate for compound 3 lay 50-fold (1.70 log units) above the measured number; the measured number lies below the stated range.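

Within the data shown here, replacing the sulfonyl with (4-bromophenyl)sulfanyl on the saturated chain carbon gives the first readable number of the series in this assay (an at least 62-fold lower number from compound 2 to compound 3 (1.79 log units; beyond the scatter)) and (an at least 62-fold lower number from compound 1 to compound 3 (1.79 log units; beyond the scatter)). The step between compound 1 and compound 2 cannot be read, and the two steps to compound 3 have only a lower bound on their size, because both sulfonyl compounds stand at a limit: the limit of > 100000 nM in this assay, at which 2 of the 3 values shown sit.

Compound 3 brings in the sulfanyl link and the bromine together, and the compounds shown do not separate the two. On these data alone, a plain phenylsulfanyl, a sulfinyl link or an amine in this place remains open.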